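Chain extension from compound 2 to compound 3

A few compounds are considered here, and "the series" means these few. Any claim that something is new, unique, unknown or untested is made for them only; others in the source may bear on it.

The series carries one shared core, seen in compound 1 `O=C(OCCCCCCO)OCCc1ccc(O)c(O)c1`, compound 2 `CCCCOC(=O)OCCc1ccc(O)c(O)c1` and compound 3 `CCCCCCCCOC(=O)OCCc1ccc(O)c(O)c1`. In an ADME assay on MRC5 cells (Homo sapiens) for inhibition, read by MTT assay, with a stated time of 72 h (on this read-out lower numbers stand for stronger inhibition and higher numbers for weaker inhibition), compound 1 gives > 50000 nM, which is a limit of the assay and not a number. In this assay compound 2 gives "not determined" (no result reported), so compound 2 stands nowhere on the numbers shown. Going by the values given here, the only value in the set is the one at the limit of > 50000 nM in this assay, at which 1 of the 2 values shown sits. Compound 3 differs from compound 2 by butyl in place of hydrogen on a saturated chain carbon, four bonds along the chain from an oxygen next to a carbonyl group. Among the compounds with values here, with no measured step to go by, the size of the step from compound 2 to compound 3 in this assay cannot be taken from the data, and the working expectation is no change beyond the scatter, in either direction. Compound 3 is estimated at 50000 nM in this assay, between 15000 nM and 150000 nM, with a strong chance that only a limit is reported again.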

Compound 3, half-maximal inhibitory concentration: 37900 nM
For compound 3 the middle estimate is 1.3-fold (0.12 log units) above the measured one; the measured number falls inside the stated range.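

Going by these compounds alone, with butyl on this saturated chain carbon, compound 3 gives 37900 nM in this assay, the only value that is a number and not a limit. Set against the hydroxy-ended chain, ethyl in place of hydroxy six bonds along the chain from an oxygen next to a carbonyl group gives an at least 1.3-fold lower number from compound 1 to compound 3 (0.12 log units; that floor lies within the scatter), so the two compounds are not separated beyond the scatter. The step from hydrogen to butyl cannot be read, as compound 2 has no result, and the remaining value in the series is a limit: the limit of > 50000 nM in this assay, at which 1 of the 3 values shown sits.

Still open, as far as these compounds go, is how the number in this assay responds to a longer chain than that of compound 3. Also open, from the compounds shown here alone, is what an amine or a carboxylic acid at the chain end would do to it.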